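Replacing Bromine with a Fluorophenyl Ring in an Acylguanidine Series

The source may report more compounds than this note shows. Statements on the series, on what has been measured and on what is new or still open speak of the compounds shown alone.

Measured compounds:
Compound 1, `Cc1cc(Br)c(S(C)(=O)=O)cc1C(=O)N=C(N)N`: 12 nM
Compound 2, `CCc1cc(Br)c(S(C)(=O)=O)cc1C(=O)N=C(N)N`: 41 nM
Compound 3, `CS(=O)(=O)c1cc(C(=O)N=C(N)N)c(Cl)cc1Cl`: 140 nM

In a functional assay for inhibition of sodium/hydrogen exchanger (Oryctolagus cuniculus) (a higher number here means a weaker inhibitor, a lower number a stronger inhibitor), compound 1 gives the lowest number of the three. Among the compounds with values here, its nearest neighbour is compound 2, with a 3.4-fold higher number from compound 1 to compound 2 (0.53 log units; beyond the scatter); compound 3 lies furthest away, and since it differs from compound 1 in more than one place, the two values alone show only that compound 3 gives a much higher number.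

Compound 4, `Cc1cc(-c2ccc(F)cc2)c(S(C)(=O)=O)cc1C(=O)N=C(N)N`, is to be measured in this assay. It differs from compound 1 in one place: 4-fluorophenyl in place of bromo on an aromatic carbon. The replaced bromo sits on an aromatic carbon ortho to a methylsulfonyl group and para to a group of 6 heavy atoms.

Within the data shown here, no measured step bears directly on this change. Among the measured compounds shown here, the only single-place step, from compound 1 to compound 2, touches the methyl group and not the bromo position, so it gives no guide to what a 4-fluorophenyl in place of bromo will do. For the measured compounds named here, with no comparable step available, compound 4 is expected to stay close to compound 1, and the expected step is a 1.7-fold higher number from compound 1 to compound 4 (0.22 log units; within the scatter), with wide uncertainty in either direction. Compound 4 is therefore estimated at 20 nM, within a range from 5 nM to 80 nM.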

Compound 4, half-maximal inhibitory concentration: 36 nM
Compound 4: middle estimate off by 1.8-fold (0.26 log units), on the low side; measured number inside the range.
By their numbers in this assay, from the lowest: compound 1; then compounds 4 and 2 (each within the scatter of the next); then compound 3.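

In this assay, the bromo position now has a step of its own: a 3.0-fold higher number from compound 1 to compound 4 (0.48 log units; beyond the scatter), a modest change that lies beyond the scatter. Within the data shown here, the position on the aromatic carbon ortho to a methylsulfonyl group therefore accepts 4-fluorophenyl, with 7 heavy atoms and a six-membered aromatic ring in place of a single bromine, at the cost of only this modest step, with compound 4 at 36 nM. Nothing available explains the direction or size of this step.

The compounds shown leave open whether this step belongs to the phenyl ring or to its fluorine, and an unsubstituted phenyl ring at this position would separate the two, while an amine or a carboxylic acid there would show how far the step depends on the kind of group entering. Going by these compounds, it also remains open whether the step seen when methyl is extended to the ethyl group of compound 2 would carry over to a compound bearing 4-fluorophenyl in place of bromo.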